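The source may hold more compounds than are shown below. What is called first, only, known or untested is meant among the compounds shown, and "the series" means these compounds.

Within the data shown here, compound 1 `CCOC(=O)c1cnnn1CCOCC1=NC(C)=C(C(=O)OC)C(c2ccccc2Cl)/C1=C(\O)OCC` is one of two compounds measured in a functional assay (aorta) with Rattus norvegicus as the target; a higher number here means a weaker inhibitor, a lower number a stronger inhibitor. In this assay compound 1 gives 100 nM, the highest of the two numbers. Compound 2 `CCO/C(O)=C1\C(COCCN2CC(=O)NC2=O)=NC(C)=C(C(=O)OC)C1c1cccc(Cl)c1Cl` gives 3.16 nM in this assay, a gap well beyond the usual scatter; compound 2 carries the same 2,5-dioxoimidazolidin-1-yl group that enters here but also differs from compound 1 in another place, so the two changes cannot be separated. Compound 3 `CCO/C(O)=C1\C(COCCN2C(=O)CNC2=O)=NC(C)=C(C(=O)OC)C1c1ccccc1Cl` has not yet been measured. It differs from compound 1 in one place: 2,5-dioxoimidazolidin-1-yl in place of 5-(ethoxycarbonyl)-1H-1,2,3-triazol-1-yl on a saturated chain carbon, two bonds along the chain from an oxygen on a saturated carbon. Among the measured compounds shown here, no step between measured compounds isolates this change. Because compound 2 gives 3.16 nM with the same entering group, the expected step is a 5.0-fold lower number from compound 1 to compound 3 (0.70 log units; beyond the scatter), toward a stronger inhibitor and beyond the scatter, though tempered by the second difference. Compound 3 is estimated at 20 nM, with a range from 5 nM to 80 nM.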

Compound 3, half-maximal inhibitory concentration: 31.6 nM
Estimate against measurement, compound 3: 1.6-fold (0.20 log units) below; low and high end bracket the measured number.
By their numbers in this assay, from the lowest: compound 2; then compound 3; then compound 1.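

Among these compounds, with only this one group changed, 2,5-dioxoimidazolidin-1-yl in place of 5-(ethoxycarbonyl)-1H-1,2,3-triazol-1-yl gives a 3.2-fold lower number from compound 1 to compound 3 (0.50 log units; beyond the scatter) in this assay, a real gain in strength as an inhibitor. The earlier pair could not show this, as compound 2 also differs from compound 1 in another place. The result also shows that the chain position accepts a smaller, non-aromatic ring carrying a hydrogen-bond donor without any loss of strength, but nothing available explains the change.

Which part of the new ring matters remains open, as the swap replaces the whole group at once. A simple amine or a carboxylic acid at this position, or a longer chain leading to the same ring, could still move the number in either direction.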